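Methyl added to a stilbene: expected effect on Nrf2

A few compounds are considered here, and "the series" means these few. Any claim that something is new, unique, unknown or untested is made for them only; others in the source may bear on it.

Measured compounds:
- compound 1, `Fc1ccccc1/C=C/c1ccccc1`, 700 nM
- compound 2, `Cc1ccc(/C=C/c2ccccc2F)cc1`, 1400 nM
- compound 3, `COc1cccc(/C=C/c2ccccc2)c1OC`, 4700 nM

All three were tested in an assay on HepG2 cells for activation of nuclear factor erythroid 2-related factor 2 (Homo sapiens), read by a luciferase reporter, with a stated time of 5 h; on this read-out lower numbers stand for an effect already at smaller amounts and higher numbers for an effect only at larger amounts of compound. Compound 1 gives 700 nM, and compound 2, which differs from it by methyl in place of hydrogen on an aromatic carbon, gives 1400 nM. The step of a 2.0-fold higher number from compound 1 to compound 2 (0.30 log units; within the scatter) is therefore small, and no order between the two compounds can be read from it. Compound 3 carries a different core; the difference between the core of compound 3 and that of compound 1 is not broken down here. Compound 3 gives 4700 nM, the highest of the three numbers, and its distance to both compound 1 and compound 2 is beyond the scatter.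

Compound 4, `COc1cccc(/C=C/c2ccc(C)cc2)c1OC`, has not yet been measured. It differs from compound 3 by methyl in place of hydrogen on an aromatic carbon. For the measured compounds named here, this is the same kind of change as the one from compound 1 to compound 2: in both cases a methyl enters on an aromatic carbon of a six-membered aromatic ring of carbon only, but here it sits para to a large group, whereas in compound 2 it sits para to a group of 9 heavy atoms.

Because the earlier step of a 2.0-fold higher number from compound 1 to compound 2 (0.30 log units; within the scatter) was small, a step of similar size, a 1.5-fold higher number from compound 3 to compound 4 (0.17 log units; within the scatter), is expected in this assay. Compound 4 is accordingly estimated at 7000 nM, with a likely range from 3000 nM to 16000 nM.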

Compound 4, half-maximal effective concentration: 1100 nM
The estimate for compound 4 lay 6.4-fold (0.80 log units) above the measured number; measured number outside the range, below it.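

In this assay, methyl in place of hydrogen on an aromatic carbon gives a 4.3-fold lower number from compound 3 to compound 4 (0.63 log units; beyond the scatter), so on the core of compound 3 this small change goes with an effect at smaller amounts of compound. For the compounds shown here, the result does not show why the same change behaves differently on the two cores, and with only two cores it gives no rule for what the methyl would do on a third. What it does show is that a step measured on one core could not be carried over as a forecast for the other, as the two steps differ by more than repeated measurements would explain: the same change on two cores in this assay, a 2.0-fold higher number (0.30 log units; within the scatter) from compound 1 to compound 2 and a 4.3-fold lower number (0.63 log units; beyond the scatter) from compound 3 to compound 4, 8.5-fold (0.93 log units) apart, beyond the scatter of two such steps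

The compounds shown leave open whether this dependence on the core is particular to methyl or also holds for other groups on the same aromatic carbon, such as an amine, a carboxylic acid or a longer chain. They also leave open how such groups would behave on the core of compound 1, where the methyl step stays within the usual scatter and so gives no clear order between compound 1 and compound 2.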